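The source may hold more compounds than are shown below. What is called first, only, known or untested is meant among the compounds shown, and "the series" means these compounds.

The measured compounds are compound 1 `O=C(O)CCn1c(=O)oc2cc(Cl)c(Cl)cc21`, compound 2 `Cc1ccc([C@@H](C)Oc2cc3onc(CCC(=O)O)c3cc2Cl)nn1` and compound 3 `C[C@@H](Oc1cc2onc(CCC(=O)O)c2cc1Cl)c1ccc(Cl)cn1`. In a physicochemical assay for solubility, with a stated time of 24 h (a lower number here means a less soluble compound, a higher number a more soluble compound), compound 1 gives 270 ug/mL, and compound 2 gives 230 ug/mL, a number within the scatter of that of compound 1. Compound 3 gives only a limit in this assay, > 620 ug/mL. Among the compounds with values here, that limit of > 620 ug/mL in this assay, at which 1 of the 3 values shown sits, is the one reading of its kind among the three. Within the data shown here, the single measured step, an at least 2.6-fold higher number from compound 2 to compound 3 (0.43 log units; beyond the scatter), changes the group on the saturated chain carbon bound to an oxygen and does not involve the site altered in compound 4 `CCOc1cc2oc(=O)n(CCC(=O)O)c2cc1Cl`, where the change is ethoxy in place of chloro on an aromatic carbon. Among the measured compounds shown here, no measured step bears on this change, so no shift beyond the scatter is expected. Compound 4 is estimated at 250 ug/mL, between 100 ug/mL and 620 ug/mL, meaning a 1.1-fold lower number from compound 1 to compound 4 (0.03 log units; within the scatter) is expected.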

Compound 4, solubility: > 1880 ug/mL
Compound 4: only a limit was reported; the forecaster's own chance of this, stated with the estimate: 15%; middle value at least 7.5-fold (0.87 log units) from the limit.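

In this assay, ethoxy in place of chloro on an aromatic carbon gives an at least 6.9-fold higher number from compound 1 to compound 4 (0.84 log units; beyond the scatter), so this position on the core of compound 1 responds to the change. The earlier measured step concerned only the group on the saturated chain carbon and could not show this. The value of compound 4 is a limit, which leaves the full size of the step unfixed: the limit of > 1880 ug/mL in this assay, at which 1 of the 4 values shown sits.

From the compounds shown here alone, what a methoxy group, a longer alkoxy chain or an amine on this aromatic carbon would give remains open.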